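Aryl ester variation on a flavanone-lignan scaffold

This account rests on a few compounds, and the source may have more. Where it says the series, first, only, none or still open, it means among the compounds named here.

The measured compounds:
Compound 1, `COc1ccc(C(=O)OCC2Oc3ccc([C@H]4Oc5cc(O)cc(O)c5C(=O)[C@@H]4O)cc3OC2c2ccc(O)c(OC)c2)cc1`: 73300 nM
Compound 2, `COc1cc(C2Oc3cc([C@H]4Oc5cc(O)cc(O)c5C(=O)[C@@H]4O)ccc3OC2COC(=O)c2cc(OC)c(OC)c(OC)c2)ccc1O`: 94800 nM
Compound 3, `COc1cc(C2Oc3cc([C@H]4Oc5cc(O)cc(O)c5C(=O)[C@@H]4O)ccc3OC2COC(=O)c2ccccc2)ccc1O`: 105000 nM

In a functional assay, read by spectrophotometry, with a stated time of 30 min (on this read-out lower numbers stand for an effect already at smaller amounts and higher numbers for an effect only at larger amounts of compound), compound 3 holds the highest of the three numbers, yet its nearest neighbour is compound 2 and its furthest is compound 1, and both of those distances lie within the scatter. The steps of a 1.4-fold higher number from compound 1 to compound 3 (0.16 log units; within the scatter) and a 1.1-fold higher number from compound 2 to compound 3 (0.04 log units; within the scatter) therefore show no change that can be read as real, nor does a 1.3-fold higher number from compound 1 to compound 2 (0.11 log units; within the scatter). Compound 4, `COc1cc(C2Oc3cc([C@H]4Oc5cc(O)cc(O)c5C(=O)[C@@H]4O)ccc3OC2COC(=O)c2cc([N+](=O)[O-])cc([N+](=O)[O-])c2)ccc1O`, has not been measured in this assay. It differs from compound 3 by 3,5-dinitrophenyl in place of phenyl on a carbonyl carbon. All three measured steps bear on this change, since each alters the aryl group on that same carbonyl carbon, and each stayed within the scatter. Among the compounds with values here, no step tested nitro groups, so the expectation rests on the indifference of this assay to the aryl ester seen so far. Compound 4 is expected to show no step beyond the scatter, a 1.1-fold lower number from compound 3 to compound 4 (0.02 log units; within the scatter). The estimate for compound 4 in this assay is 100000 nM, with a range from 40000 nM to 250000 nM.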

Compound 4, half-maximal effective concentration: 205000 nM
Estimate against measurement, compound 4: 2.1-fold (0.31 log units) below; measured number inside the range.
By their numbers in this assay, from the lowest: compounds 1, 2, 3 and 4 (each within the scatter of the next, the first and the last beyond it).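

In this assay, within the data shown here, the aryl group on the carbonyl carbon turns out not to be entirely silent: 3,5-dinitrophenyl gives a 2.2-fold higher number from compound 2 to compound 4 (0.33 log units; beyond the scatter) in place of 3,4,5-trimethoxyphenyl and a 2.8-fold higher number from compound 1 to compound 4 (0.45 log units; beyond the scatter) in place of 4-methoxyphenyl, the only steps at this position that pass beyond the scatter, and both are modest. Against plain phenyl the same group gives a 2.0-fold higher number from compound 3 to compound 4 (0.29 log units; within the scatter) and so remains unresolved from compound 3. Nothing available accounts for these steps.

The compounds shown leave open whether the nitro groups themselves matter or the methoxy groups they replace. They also leave open how an aryl ring bearing an amine or a carboxylic acid, or a longer alkyl chain on the carbonyl carbon, would read in this assay on the same core.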